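Chloro to fluoro swap: from compound 3 toward compound 4

The compounds below may be only part of what the source reports. "The series", "measured", "known", "first", "only" and "open" are said of these compounds alone.

For the measured compounds named here, compound 1 `Fc1ccccc1Cn1cc(CSC(=S)N2CCNCC2)nn1` is the only member of the series with a number: in a functional assay on MCF7 cells (Homo sapiens) for inhibition, read by MTT assay, with a stated time of 72 h (a higher number here means a weaker inhibitor, a lower number a stronger inhibitor), compound 1 gives 33200 nM. Compound 2 `COc1ccc(Cn2cc(CSC(=S)N3CCNCC3)nn2)cc1` gives "not determined" (no result reported) in this assay, and compound 3 `S=C(SCc1cn(Cc2ccc(Cl)cc2)nn1)N1CCNCC1` gives "not determined" (no result reported) in this assay; for both the outcome was not determined. Compound 3 therefore stands nowhere on the numbers shown, and no measured pair differing in one place exists to set a step size. Compound 4 `Fc1ccc(Cn2cc(CSC(=S)N3CCNCC3)nn2)cc1` differs from compound 3 in one place: fluoro in place of chloro on an aromatic carbon. Going by the values given here, with no step recorded, the move from compound 3 to compound 4 in this assay is expected to stay within the scatter, direction unknown. Because compound 1 gives 33200 nM in this assay, compound 4 is expected near 30000 nM, within 8000 nM to 100000 nM.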

Compound 4, half-maximal inhibitory concentration: 49900 nM
Compound 4: the middle estimate sits 1.7-fold (0.22 log units) below what was measured, and the stated range covers the measured number.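

For the compounds shown here, the step of a 1.5-fold higher number from compound 1 to compound 4 (0.18 log units; within the scatter) in this assay is the first measurable one, with 4-fluorophenyl in place of 2-fluorophenyl. At this position, moving the fluoro group around the aromatic ring therefore gives a difference within the usual scatter. Nothing available explains this result. The steps to compound 2 and compound 3 cannot be read, and this includes the chloro to fluoro change. Going by these compounds, whether an amine or a carboxylic acid on this aromatic ring would separate from compound 4 remains open.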